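Compound 3 to compound 4: a sulfanyl chain change

The source may report more compounds than this note shows. Statements on the series, on what has been measured and on what is new or still open speak of the compounds shown alone.

In an ADME assay on cells (Homo sapiens) for cytotoxicity, read by resazurin assay, with a stated time of 5 days (on this read-out higher numbers stand for lower toxicity in this test and lower numbers for higher toxicity in this test), compound 1 (`COc1ccc(-c2nc(C(C)(C)S(=O)(=O)c3cccc(Cl)c3)nc3ccsc23)cn1`) reads > 50000 nM as a limit of the assay and not a number. Compound 2 (`O=S(=O)(Cc1nc(-c2ccncc2)c2sccc2n1)c1cccc(Cl)c1`) reads > 50000 nM as a limit too. Compound 3 (`COc1ccc(-c2nc(CCc3cccc(Cl)c3)nc3ccsc23)cn1`) reads > 50000 nM as a limit as well, so it has no numerical value. The whole set stands at the limit of > 50000 nM in this assay, at which 3 of the 3 values shown sit, and cannot be ranked.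

Compound 4 (`COc1ccc(-c2nc(CSCc3cccc(Cl)c3)nc3ccsc23)cn1`) carries (3-chlorobenzyl)sulfanyl in place of 3-chlorobenzyl on a saturated chain carbon bound to an aromatic carbon.

Among the measured compounds shown here, no measured step is available for this kind of change. Because compound 3 reads > 50000 nM as a limit, no shift beyond the scatter is expected in this assay in either direction. The estimated change, a number no higher from compound 3 to compound 4 (the limit leaves the size open), is expected to stay within the scatter. For compound 4 the estimated value is 50000 nM with an expected range from 25000 nM to 100000 nM on the same scale.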

Compound 4, half-maximal cytotoxic concentration: > 50000 nM
Compound 4 gave a limit, no number (the forecaster's own chance of this, stated with the estimate: 75%); the middle value sits exactly at the limit.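

No step can be read between compound 3 and compound 4, because both values are limits and not numbers: the limit of > 50000 nM in this assay, at which 4 of the 4 values shown sit.

The compounds shown leave open at what concentration any of them turns cytotoxic, and whether the change from compound 3 to compound 4 alters that concentration.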